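Removing a methyl group from compound 3

A few compounds are considered here, and "the series" means these few. Any claim that something is new, unique, unknown or untested is made for them only; others in the source may bear on it.

- Compound 1 `c1ccc(-c2cccc(Oc3cccc(Cn4ccnc4)c3)c2)cc1`: 34000 nM
- Compound 2 `Cc1cccc(Oc2cccc(Cn3ccnc3)c2)c1`: 78700 nM
- Compound 3 `Cc1ccccc1Oc1cccc(Cn2ccnc2)c1`: 79300 nM

In an ADME assay on NIH3T3 cells (Mus musculus) for cytotoxicity (a higher number here means that more compound is needed for the effect, a lower number that less compound is needed), compound 3 gives 79300 nM, level with compound 2 at 78700 nM. Compound 3 has a higher number than compound 1, which gives 34000 nM. Compound 4 `c1ccc(Oc2cccc(Cn3ccnc3)c2)cc1` differs from compound 3 as follows: hydrogen in place of methyl on an aromatic carbon. This puts hydrogen in place of methyl on an aromatic carbon, ortho to a large group. Among the compounds with values here, the one measured step that bears on this is a 2.3-fold higher number from compound 1 to compound 2 (0.36 log units; beyond the scatter), a modest change that swaps phenyl for methyl. Losing a single methyl is a smaller exchange, so no change beyond the scatter is expected. The expected step is a 1.0-fold higher number from compound 3 to compound 4 (0.00 log units; within the scatter). For compound 4 the estimate is 80000 nM, with an expected range from 45000 nM to 140000 nM.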

Compound 4, half-maximal effective concentration: > 100000 nM
Compound 4 was reported as a limit; the forecaster's own chance of this, stated with the estimate: 10%; at least 1.2-fold (0.09 log units) between middle value and limit.
By their numbers in this assay, from the lowest: compound 1; then compounds 2 and 3 (each within the scatter of the next). At a limit, above all of these: compound 4.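

In this assay compound 4 reaches a limit of the assay, not a number: the limit of > 100000 nM in this assay, at which 1 of the 4 values shown sits.
The methyl steps therefore give only floors, with an at least 1.2-fold higher number from compound 3 to compound 4 (0.10 log units; that floor lies within the scatter) and an at least 1.2-fold higher number from compound 2 to compound 4 (0.10 log units; that floor lies within the scatter) being all that can be said about taking the methyl away. Within the data shown here, replacing the phenyl with hydrogen gives a clearer result, with an at least 2.9-fold higher number from compound 1 to compound 4 (0.46 log units; beyond the scatter) as the one step here that is beyond the scatter.

On these data alone, how far compound 4 really lies past its limit stays open, so the full size of these steps is unknown. As far as these compounds go, whether an amine or a carboxylic acid on this aromatic carbon would shift the number also remains open.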